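This account rests on a few compounds, and the source may have more. Where it says the series, first, only, none or still open, it means among the compounds named here.

For the measured compounds named here, in a functional assay on HeLa cells (Homo sapiens) for antiproliferative activity, read by sulforhodamine B assay (on this read-out lower numbers stand for stronger inhibition and higher numbers for weaker inhibition), three compounds on the shared core have values so far: compound 1 `C/C(=N\Nc1nc2ccccc2o1)c1cnc(C)cn1` gives 370 nM, compound 2 `C/C(=N\Nc1nc2ccccc2o1)c1ncccn1` gives 180 nM, and compound 3 `C/C(=N\Nc1nc2ccccc2o1)c1nccnc1C` gives 1860 nM. Compound 3 has the highest number of the three, beyond the scatter from both others. Compound 4 `C/C(=N\Nc1nc2ccccc2o1)c1cnccn1` differs from compound 3 by hydrogen in place of methyl on an aromatic carbon. Going by the values given here, no measured pair isolates this change, so the expectation rests on the values alone. Compound 1 at 370 nM and compound 2 at 180 nM suggest a lower number without this methyl. The estimated step, expected to lie beyond the scatter, is a 6.2-fold lower number from compound 3 to compound 4 (0.79 log units; beyond the scatter). Compound 4 is estimated at 300 nM, with an expected range of 100 nM to 900 nM.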

Compound 4, half-maximal inhibitory concentration: 690 nM
Compound 4: middle estimate off by 2.3-fold (0.36 log units), on the low side, and the stated range covers the measured number.
By their numbers in this assay, from the lowest: compound 2; then compounds 1 and 4 (each within the scatter of the next); then compound 3.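

In this assay, removing the methyl next to the ring nitrogen and ortho to a large group gives a 2.7-fold lower number from compound 3 to compound 4 (0.43 log units; beyond the scatter), a real gain at this position. The same exchange with the methyl placed elsewhere on the ring gives a 1.9-fold higher number from compound 1 to compound 4 (0.27 log units; within the scatter), so among these compounds the result depends on where the methyl sits. Ring nitrogen placement also matters, with a 3.8-fold higher number from compound 2 to compound 4 (0.58 log units; beyond the scatter) as the step from the pyrimidin-2-yl to the pyrazin-2-yl compound.

No available measurement explains these differences. As far as these compounds go, whether ethyl, methoxy, chlorine or an amine at this position would behave like methyl or like hydrogen remains open.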